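The compounds below may be only part of what the source reports. "The series", "measured", "known", "first", "only" and "open" are said of these compounds alone.

Compound 1 `Cn1c(CC23CCCC[C@@H]2O3)cc(=O)n(C)c1=O`: 40000 nM
Compound 2 `Cn1c([C@H]2O[C@H]2c2ccccc2)cc(=O)n(C)c1=O`: 7700 nM

In a functional assay on MDCK cells (Canis lupus familiaris) for inhibition (on this read-out lower numbers stand for higher toxicity in this test and higher numbers for lower toxicity in this test), compound 2 gives 7700 nM, the lower of the two numbers and so the higher toxicity. Compound 1 gives 40000 nM, and this gap lies beyond the usual scatter. Compound 3 `Cn1c([C@H]2O[C@@H]2c2ccccc2)cc(=O)n(C)c1=O` has not yet been measured. Its difference from compound 2 is purely one of configuration: the two compounds have the same atoms and bonds and differ only in configuration as drawn: 1 of 2 stereo elements differ; a stereocentre at a saturated ring carbon is drawn S in compound 2 and R in compound 3. Among the measured compounds shown here, no measured pair of compounds shows what such a change does in this assay, so the expectation is anchored on compound 2 at 7700 nM and its direction is uncertain. The expected change is small and stays within the scatter, an estimated 1.2-fold higher number from compound 2 to compound 3 (0.07 log units; within the scatter). For compound 3 the expected value is 9000 nM, with an estimated range of 3500 nM to 25000 nM.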

Compound 3, half-maximal cytotoxic concentration: > 380000 nM
Compound 3 ended at the assay's limit; the forecaster's own chance of this, stated with the estimate: 8%; at least 42-fold (1.62 log units) between middle value and limit.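

In this assay compound 3 gives > 380000 nM, which is a limit of the assay and not a number. Changing one stereocentre at a saturated ring carbon from S to R, with atoms and bonds left as they are, gives an at least 49-fold higher number from compound 2 to compound 3 (1.69 log units; beyond the scatter), so in this test a single change of configuration at this position is enough for a large step. Compound 1 and compound 2 differ in more than one place and could not show this, whereas here the whole step belongs to the configuration: the fact that compounds 2 and 3 differ only in the configuration as drawn.

As far as these compounds go, what the other stereo element does when it alone changes stays open. So does whether an amine or a methoxy group, added in the same place to compound 2 and compound 3, would keep a gap of this size between them.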